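The source may report more compounds than this note shows. Statements on the series, on what has been measured and on what is new or still open speak of the compounds shown alone.

Measured compounds:
- Compound 1 `CCNCC1CCN(c2c(F)cc3c(=O)c(C(=O)O)cn(CC)c3c2F)C1`, in a functional assay on V79 cells (Cricetulus griseus) for cytotoxicity, read by colony formation; a higher number here means a weaker inhibitor, a lower number a stronger inhibitor: 160 ug/mL
- Compound 2 `CCn1cc(C(=O)O)c(=O)c2cc(F)c(N3CCC(N)C3)c(F)c21`, in this assay: 300 ug/mL
- Compound 3 `NC1CCN(c2c(F)c(Cl)c3c(=O)c(C(=O)O)cn(C4CC4)c3c2Cl)C1`, in this assay: reported only as a limit, > 500 ug/mL

Compounds 1 and 2 share one core and differ in a single place. The difference is (ethylamino)methyl in place of amino on a saturated ring carbon, and the step it made is a 1.9-fold lower number from compound 2 to compound 1 (0.27 log units; within the scatter), so the two values say nothing more than that the change left the read-out where it was. Compound 3 carries a different core, and the difference between the two cores is not broken down here. For compound 3 the assay gives a limit rather than a number, (the limit of > 500 ug/mL in this assay, at which 1 of the 3 values shown sits).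

Compound 4 `CCNCC1CCN(c2c(F)c(Cl)c3c(=O)c(C(=O)O)cn(C4CC4)c3c2Cl)C1` is not yet measured in this assay. It stands to compound 3 as compound 1 stands to compound 2: the difference is (ethylamino)methyl in place of amino on a saturated ring carbon, the same change made once more, on the same kind of place. Because the earlier instance of this change gave a 1.9-fold lower number from compound 2 to compound 1 (0.27 log units; within the scatter), the expectation is that the read-out of compound 4 will also stay where compound 3 sits, that is, at or around the limit. For compound 4 the expected step is a number no higher from compound 3 to compound 4 (the limit leaves the size open), which rests on the measured step of a 1.9-fold lower number from compound 2 to compound 1 (0.27 log units; within the scatter) and on the limit reported for compound 3. Compound 4 is therefore estimated at about 500 ug/mL, with a range from 250 ug/mL to 1000 ug/mL, and it is expected that the assay may again report only a limit.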

Compound 4, half-maximal inhibitory concentration: 270 ug/mL
For compound 4 the middle estimate is 1.9-fold (0.27 log units) above the measured one, and the stated range covers the measured number.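

Carried onto the second core, the change from amino to (ethylamino)methyl on a saturated ring carbon gave an at least 1.8-fold lower number from compound 3 to compound 4 (0.26 log units; that floor lies within the scatter) in this assay. From the compounds shown here alone, on both cores the change went with a lower number or, on the first core, with no change beyond the scatter, so this second instance gives no sign of a reversal, and the comparison between the two instances reaches only this far: the same change on two cores in this assay, a 1.9-fold lower number (0.27 log units; within the scatter) from compound 2 to compound 1 and an at least 1.8-fold lower number (0.26 log units; that floor lies within the scatter) from compound 3 to compound 4; the limit leaves it open whether they differ The entry for compound 3 is a limit and not a number, so the full size of the second step stays unknown, and the data show neither that the change has the same size on both cores nor that it is larger on one of them, while two cores are too few to set a rule for the series.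

The compounds shown leave open how other groups would read in the same place, such as a primary aminomethyl, a dimethylamino or an ethylamino chain lengthened to a propylamino. They also leave open what each of the differences between the two cores contributes on its own, as no pair shown separates them.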